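This account rests on a few compounds, and the source may have more. Where it says the series, first, only, none or still open, it means among the compounds named here.

Working notes on the series. Going by the values given here, compound 1 `Cc1nc(N)sc1CCCN/C(N)=N/C(=O)N[C@H](C)c1ccccc1` carries a 1-phenylethyl group on the urea nitrogen and is the more potent of the two compounds measured so far: in a functional assay on HEK293T cells for agonist activity at histamine H2 receptor (Homo sapiens), read by beta-arrestin recruitment (a lower number here means that less compound is needed, a higher number that more compound is needed for the effect), compound 1 gives 45.7 nM. Among the compounds with values here, the only other measured member is compound 2 `Cc1nc(N)sc1CCCN/C(N)=N/C(=O)NC(c1ccccc1)c1ccccc1`, which bears a diphenylmethyl group at the same position; in this assay compound 2 gives 331 nM, a higher number than compound 1 by a margin that lies beyond the usual scatter. Within the data shown here, no step between these two has been computed, so their two values alone show that the larger substituent on this nitrogen goes with a weaker result.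

Compound 3 `Cc1nc(N)sc1CCCN/C(N)=N/C(=O)Nc1ccccc1` has not yet been measured. It differs from compound 1 in one place: phenyl in place of 1-phenylethyl on an amide-type nitrogen. Because compound 2 gives 331 nM after enlarging the group on this nitrogen, the opposite move to a smaller group is not expected to cost much, but with only two points no direction is firmly supported. The step from compound 1 to compound 3 in this assay is expected to be a 1.5-fold higher number from compound 1 to compound 3 (0.19 log units; within the scatter), within or close to the scatter. For compound 3 the estimate in this assay is 70 nM, with a range from 20 nM to 250 nM.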

Compound 3, half-maximal effective concentration: 3390 nM
Compound 3: the middle estimate sits 48-fold (1.69 log units) below what was measured; measured number above the stated range.
By their numbers in this assay, from the lowest: compound 1; then compound 2; then compound 3.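

In this assay, the change from 1-phenylethyl to phenyl on this amide-type nitrogen is a large step, a 74-fold higher number from compound 1 to compound 3 (1.87 log units; beyond the scatter), so the position is sensitive to a small change in its substituent and not only to enlargement. The earlier link between a larger group and a weaker result does not hold across the three compounds: compound 3, with the smallest group, gives 3390 nM and goes against that pattern, while compound 2, with the largest group, gives 331 nM and compound 1, with the intermediate group, gives the lowest number. No available measurement explains the size of this step.

The step removes the defined stereocentre together with the two extra carbons of 1-phenylethyl, and the compounds shown cannot separate these features, which a benzyl group or the opposite enantiomer of compound 1 would help to do. A 2-phenylethyl group or a cyclohexyl group on the same nitrogen would also show whether the result depends on the chain length or on the aromatic ring.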